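From methylcarbamoyl to piperazinylcarbonyl at the assay limit

The source may hold more compounds than are shown below. What is called first, only, known or untested is meant among the compounds shown, and "the series" means these compounds.

Compound 3 `CNC(=O)c1oc2ccc(Nc3ncnc4ccc(Cl)nc34)cc2c1C` sits at the limit of an assay on isolated protein for inhibition of MAP kinase-interacting serine/threonine-protein kinase 1 (Homo sapiens), read by HTRF, in the presence of a further agent that is not named here (on this read-out lower numbers stand for stronger inhibition and higher numbers for weaker inhibition), where it gives > 10000 nM, a limit of the assay and not a number. Compound 1 `CCCNC(=O)c1cccc(C#Cc2ccccc2Nc2ncnc3ccc(Cl)nc23)c1` in this assay also gives > 10000 nM, again a limit. Compound 2 `O=C(c1cccc(C#Cc2ccccc2Nc2ncnc3ccc(Cl)nc23)c1)N1CCOCC1` gives > 10000 nM, once more a limit. Among the compounds with values here, the single measured step, a step that the two limits leave unreadable from compound 1 to compound 2, is therefore unreadable, and the limit of > 10000 nM in this assay, at which 3 of the 3 values shown sit, is all that the numbers offer. Compound 4 `Cc1c(C(=O)N2CCNCC2)oc2ccc(Nc3ncnc4ccc(Cl)nc34)cc12` differs from compound 3 by piperazin-1-yl in place of methylamino on a carbonyl carbon. No readable step bears on this change, so no direction beyond the scatter can be argued. The estimate for compound 4 in this assay is 15000 nM, with a range from 3000 nM to 60000 nM, and the expected step that the limit leaves unreadable from compound 3 to compound 4 most likely leaves compound 4 at the limit.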

Compound 4, half-maximal inhibitory concentration: > 10000 nM
Compound 4 ended at the assay's limit; the forecaster's own chance of this, stated with the estimate: 75%; the middle value does not contradict the limit.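

No step can be read between compound 3 and compound 4, since both values in this assay are limits and not numbers: the limit of > 10000 nM in this assay, at which 4 of the 4 values shown sit.

The compounds shown leave open which change on the carbonyl carbon, if any, would give a value inside the limit.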